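The source may report more compounds than this note shows. Statements on the series, on what has been measured and on what is new or still open speak of the compounds shown alone.

Compound 3 `O=S(=O)(NCCCN1CCN(c2ccc(C(F)(F)F)cc2)CC1)c1ccc2ccccc2c1` stands highest of the two numbers measured in an assay on CHO cells for displacement of a labelled ligand from 5-hydroxytryptamine receptor 7 (Homo sapiens) (on this read-out higher numbers stand for weaker inhibition and lower numbers for stronger inhibition), where compound 3 gives 567 nM. Its nearest neighbour is compound 1 `COc1ccc(S(=O)(=O)NCCCN2CCN(c3ccc(C(F)(F)F)cc3)CC2)cc1`; in this assay compound 1 gives 384 nM, and the change between them was a 1.5-fold higher number from compound 1 to compound 3 (0.17 log units; within the scatter). Compound 2 `COc1ccc(S(=O)(=O)NCCCN2CCN(C(=O)c3ccco3)CC2)cc1` gives in this assay only the limit > 10000 nM. The step to compound 2 was an at least 26-fold higher number from compound 1 to compound 2 (1.41 log units; beyond the scatter), showing that the group on the amine nitrogen in the ring can matter greatly. Compound 4 `COc1ccc(N2CCN(CCCNS(=O)(=O)c3ccc4ccccc4c3)CC2)cc1` differs from compound 3 by methoxy in place of trifluoromethyl on an aromatic carbon. Among the measured compounds shown here, no measured step tests this exact exchange; the aryl group on that nitrogen stays, so only a modest shift is expected, a 1.2-fold higher number from compound 3 to compound 4 (0.09 log units; within the scatter). For compound 4 the expected value is 700 nM, between 250 nM and 2500 nM.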

Compound 4, half-maximal inhibitory concentration: 3240 nM
The estimate for compound 4 lay 4.6-fold (0.67 log units) below the measured number, outside the stated range (above it).
By their numbers in this assay, from the lowest: compounds 1 and 3 (each within the scatter of the next); then compound 4. At a limit, above all of these: compound 2.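

Keeping an aryl group on the ring nitrogen is not enough to hold the number in this assay steady: methoxy in place of trifluoromethyl gives a 5.7-fold higher number from compound 3 to compound 4 (0.76 log units; beyond the scatter) even though only one small group on an aromatic carbon changes. Before this, the only step beyond the scatter replaced the whole aryl group, while the change on the sulfonyl sulfur stayed within it. Nothing shown explains why these two groups differ.

On these data alone, it remains open whether the same exchange has a similar effect with the 4-methoxyphenyl group of compound 1 on the sulfonyl sulfur. As far as these compounds go, how a chlorine, a nitrile or an amine would compare at this place also remains open.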